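The source may report more compounds than this note shows. Statements on the series, on what has been measured and on what is new or still open speak of the compounds shown alone.

Measured so far, in a functional assay on PC-3 cells (Homo sapiens) for cytotoxicity, read by MTT assay, with a stated time of 72 h; on this read-out higher numbers stand for weaker inhibition and lower numbers for stronger inhibition:

Compound 1, `COc1ccc(C(=O)c2cc(OC)c(OC)c(OC)c2)cc1N`: 1100 nM
Compound 2, `COc1ccc(C(=O)c2cc(OC)c(OC)c(OC)c2)cc1NC(=O)/C=C/c1ccc(F)cc1`: 3200 nM
Compound 3, `COc1ccc(C(=O)c2cc(OC)c(OC)c(OC)c2)cc1NC(=O)/C=C/c1ccc(N)cc1`: 15900 nM

Compound 1 gives the lowest number of the three in this assay, so it is the strongest inhibitor shown. The step of a 2.9-fold higher number from compound 1 to compound 2 (0.46 log units; beyond the scatter) and the step of a 14-fold higher number from compound 1 to compound 3 (1.16 log units; beyond the scatter) both weaken inhibition, and the step of a 5.0-fold higher number from compound 2 to compound 3 (0.70 log units; beyond the scatter) separates the two acylated compounds.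

Compound 4, `COc1cc(C(=O)c2cc(OC)c(OC)c(OC)c2)cc(N)c1OC`, keeps the free amino group of compound 1 and differs from it only by methoxy in place of hydrogen on an aromatic carbon. For the measured compounds named here, none of the measured steps touches that position: each of them changes the amino nitrogen or a group on the distant ring. Going by the values given here, no measured step therefore bears directly on this change, and the expectation must rest on the small size of the added group alone. For compound 4 in this assay a step of a 1.4-fold higher number from compound 1 to compound 4 (0.13 log units; within the scatter) is expected, with no confident direction. The estimated value for compound 4 is 1500 nM, with a range from 400 nM to 6000 nM.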

Compound 4, half-maximal inhibitory concentration: 7400 nM
Compound 4: middle estimate off by 4.9-fold (0.69 log units), on the low side; measured number above the stated range.
By their numbers in this assay, from the lowest: compound 1; then compound 2; then compound 4; then compound 3.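

In this assay the added methoxy group gives a 6.7-fold higher number from compound 1 to compound 4 (0.83 log units; beyond the scatter) and so shows that this aromatic carbon, ortho to a methoxy group and meta to the amino group, is sensitive to substitution. The earlier steps shown here changed only the amino nitrogen or the group attached to it, whereas this one shows that inhibition can also weaken when the free amino group stays in place and the change is made elsewhere on its ring. Nothing available here accounts for this loss of inhibition.

The compounds shown leave open whether any group on this carbon weakens inhibition or whether methoxy does so in particular, a question that a hydroxy group or a longer ethoxy chain here could help settle. Going by these compounds, it also remains open whether compound 2 and compound 3 would respond in the same way to a methoxy group at this carbon.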